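Varying the piperazin-1-yl group: from compound 2 to compound 4

This account rests on a few compounds, and the source may have more. Where it says the series, first, only, none or still open, it means among the compounds named here.

Compound 2 `C[C@@H]1CN(c2cccc3c2C[C@H](CN(C)[C@H]2CCCc4cccnc42)NC3)C[C@H](C)N1` stands lowest of the three numbers in a functional assay on CCRF-CEM cells for antagonist activity at C-X-C chemokine receptor type 4 (Homo sapiens), read by calcium flux, with stated times of 25 min and 90 s (on this read-out lower numbers stand for stronger inhibition and higher numbers for weaker inhibition), where compound 2 gives 61 nM. Compound 3 `CN(C[C@@H]1Cc2c(cccc2N2CCNCC2)CN1)[C@H]1CCCc2cccnc21` gives 313 nM in this assay. Compound 1 `CN(C[C@H]1Cc2c(cccc2N2CCN(C3COC3)CC2)CN1)[C@H]1CCCc2cccnc21` gives 381 nM in this assay. Among the measured compounds shown here, the only single-place step measured so far is a 6.2-fold lower number from compound 1 to compound 2 (0.80 log units; beyond the scatter), in which 3,5-dimethylpiperazin-1-yl replaces 4-(oxetan-3-yl)piperazin-1-yl on an aromatic carbon.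

Compound 4 `CN(C[C@H]1Cc2c(cccc2N2CCN(C3CC3)CC2)CN1)[C@H]1CCCc2cccnc21` is not yet measured. It differs from compound 2 in one place: 4-cyclopropylpiperazin-1-yl in place of 3,5-dimethylpiperazin-1-yl on an aromatic carbon.

This change runs in the opposite sense to the measured step, since the 3,5-dimethylpiperazin-1-yl that lowered the number leaves, and a piperazin-1-yl bearing a cyclopropyl group, in the manner of the oxetan-3-yl group of compound 1, enters. For the measured compounds named here, no step between compound 2 and compound 3 was worked out; their two values simply show compound 3 well above compound 2 and close to compound 1. On this basis a step back upward of roughly the measured size is expected, landing compound 4 near the values of compound 1 and compound 3.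

Compound 4 is therefore expected at 260 nM, with a range of 100 nM to 700 nM. This corresponds to an expected 4.3-fold higher number from compound 2 to compound 4 (0.63 log units; beyond the scatter).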

Compound 4, half-maximal inhibitory concentration: 23.5 nM
For compound 4 the middle estimate is 11-fold (1.04 log units) above the measured one, and the stated range ends above it.
By their numbers in this assay, from the lowest: compound 4; then compound 2; then compounds 3 and 1 (each within the scatter of the next).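

In this assay, the substituent on the amine nitrogen of the piperazine ring emerges as a strong determinant of the number: with only this place changed, cyclopropyl in place of oxetan-3-yl gives a 16-fold lower number from compound 1 to compound 4 (1.21 log units; beyond the scatter). A substituent on that nitrogen is therefore compatible with a low number, and 4-cyclopropylpiperazin-1-yl compares favourably with the 3,5-dimethylpiperazin-1-yl group on the same aromatic carbon, with a 2.6-fold lower number from compound 2 to compound 4 (0.41 log units; beyond the scatter), so the high number of compound 1 goes with the oxetan-3-yl group and not with substitution on that nitrogen as such. Nothing available here accounts for either step.

The compounds shown leave open whether the low number is particular to cyclopropyl or extends to other small carbon groups on that nitrogen, such as methyl, isopropyl or cyclobutyl, and how a more polar substituent such as 2-hydroxyethyl or acetyl would compare with oxetan-3-yl. From the compounds shown here alone, it is also open whether cyclopropyl on that nitrogen and the two methyl groups of the 3,5-dimethylpiperazin-1-yl group could be combined in one piperazine ring, and how such a compound would compare with compound 4.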